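A Methyl Added to the Core of Compound 1

The source may report more compounds than this note shows. Statements on the series, on what has been measured and on what is new or still open speak of the compounds shown alone.

Within the data shown here, compound 1 `CCS[C@@H]1[C@H](SCC)[C@@H](Cn2cc(-c3ccc(C)cc3)nn2)O[C@H]1n1ccc(=O)[nH]c1=O` gives 6780 nM in a functional assay on A549 cells (Homo sapiens) for cytotoxicity, read by MTT assay, with a stated time of 72 h (on this read-out lower numbers stand for an effect already at smaller amounts and higher numbers for an effect only at larger amounts of compound), the lowest of the two numbers known so far. Compound 2 `CCS[C@@H]1[C@H](SCC)[C@@H](Cn2cc(-c3cccc(C)c3)nn2)O[C@H]1n1ccc(=O)[nH]c1=O` gives 12200 nM in this assay. Among the measured compounds shown here, the one measured step, a 1.8-fold higher number from compound 1 to compound 2 (0.26 log units; within the scatter), lies within the scatter and concerns the methylphenyl, not the place changed here. Compound 3 `CCS[C@@H]1[C@H](SCC)[C@@H](Cn2cc(-c3ccc(C)cc3)nn2)O[C@H]1n1cc(C)c(=O)[nH]c1=O` differs from compound 1 by methyl in place of hydrogen on an aromatic carbon. For the measured compounds named here, no measured step touches this position, so nothing points in either direction. For compound 3 the expected step is a 1.0-fold higher number from compound 1 to compound 3 (0.00 log units; within the scatter), within the scatter. Compound 3 is therefore estimated at 6800 nM, with a range from 2500 nM to 18000 nM.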

Compound 3, half-maximal effective concentration: 12300 nM
Estimate against measurement, compound 3: 1.8-fold (0.26 log units) below, and the stated range covers the measured number.
By their numbers in this assay, from the lowest: compounds 1, 2 and 3 (each within the scatter of the next).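

In this assay, methyl in place of hydrogen on this aromatic carbon gives a 1.8-fold higher number from compound 1 to compound 3 (0.26 log units; within the scatter) and so stays within the scatter. This first reading at the position therefore shows that this single added methyl cannot be told apart from no change. No evidence is at hand that bears on this result.

From the compounds shown here alone, whether an ethyl group, an amine or a chlorine atom at this place would move the number beyond the scatter stays open. So does whether methyl here would behave the same alongside the 3-methylphenyl group of compound 2.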